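Hydrazone series, cytotoxicity: the hydroxy analogue of compound 1

This account rests on a few compounds, and the source may have more. Where it says the series, first, only, none or still open, it means among the compounds named here.

Measured compounds:
compound 1 `O=C(N/N=C/c1ccccc1)c1cccnc1`: > 125 ug/mL
compound 2 `O=C(N/N=C/c1ccc(Cl)cc1)c1cccnc1`: 76 ug/mL
compound 3 `O=C(N/N=C/c1ccc([N+](=O)[O-])cc1)c1cccnc1`: 0.1 ug/mL

In an ADME assay on MT4 cells (Homo sapiens) for cytotoxicity, read by MTT assay, with a stated time of 4 days (a higher number here means that more compound is tolerated, a lower number that less compound is tolerated), compound 1 gives > 125 ug/mL, which is a limit of the assay and not a number (the limit of > 125 ug/mL in this assay, at which 1 of the 3 values shown sits). So compound 1 stands at the tolerated end of the three values shown, with its exact value unknown. Compound 2 gives 76 ug/mL in this assay and compound 3 gives 0.1 ug/mL.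

Compound 4 `O=C(N/N=C/c1cccc(O)c1)c1cccnc1` differs from compound 1 by hydroxy in place of hydrogen on an aromatic carbon.

Two measured steps start from compound 1. The chloro step, an at least 1.6-fold lower number from compound 1 to compound 2 (0.21 log units; that floor lies within the scatter), is small. The nitro step, an at least 1200-fold lower number from compound 1 to compound 3 (3.09 log units; beyond the scatter), is large, and the related step of a 760-fold lower number from compound 2 to compound 3 (2.88 log units; beyond the scatter) is large as well. Among the measured compounds shown here, the hydroxy group entering in compound 4 is neither chloro nor nitro, so no measured step bears on it directly; the only large drop seen comes with nitro, and the other substitution seen, chloro, stays within the scatter.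

The expectation for compound 4 is therefore a step of no more than the scatter, an at least 1.0-fold lower number from compound 1 to compound 4 (0.01 log units; that floor lies within the scatter), and the value is expected to sit again at or near the assay limit. Compound 4 is estimated at 120 ug/mL in this assay, with a range of 45 ug/mL to 250 ug/mL.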

Compound 4, half-maximal cytotoxic concentration: 98 ug/mL
Beside the measured number, compound 4's estimate is 1.2-fold (0.09 log units) above it; the range from low to high includes it.
By their numbers in this assay, from the lowest: compound 3; then compounds 2 and 4 (each within the scatter of the next). At a limit, above all of these: compound 1.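

In this assay compound 4 is the only one shown with a group on an aromatic carbon meta to a large group, and with hydroxy at that place compound 4 gives a real reading of 98 ug/mL rather than a limit. Going by these compounds, the step reads an at least 1.2-fold lower number from compound 1 to compound 4 (0.10 log units; that floor lies within the scatter), so only a floor can be taken from it, and the true size of this change stays unknown, whether small or larger. The value of compound 1 is a limit and not a number, which is what restricts this step to a floor: the limit of > 125 ug/mL in this assay, at which 1 of the 4 values shown sits.

Still open, on these data alone, is whether chloro or nitro on this same carbon would repeat the numbers of compound 2 and compound 3, which would show whether the large step of an at least 1200-fold lower number from compound 1 to compound 3 (3.09 log units; beyond the scatter) goes with the nitro group alone or also with its place on the ring. Also open, as far as these compounds go, is how an amine, a carboxylic acid or a methoxy group at this place would read against compound 4.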